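The source may report more compounds than this note shows. Statements on the series, on what has been measured and on what is new or still open speak of the compounds shown alone.

Measured so far:
compound 1, `COc1cc(C2=NOC(CO[C@@H]3O[C@H](CSc4ncn[nH]4)[C@H]4OC5(CCCC5)O[C@@H]34)C2)cc(OC)c1OC`, giving 38000 nM
compound 2, `CC(=O)OC[C@H]1O[C@@H](OCc2noc(-c3ccc([N+](=O)[O-])cc3)n2)[C@@H]2OC3(CCCC3)O[C@@H]21`, giving 17000 nM

In a functional assay on HeLa cells (Homo sapiens) for antiproliferative activity, read by sulforhodamine B assay, with a stated time of 48 h (a lower number here means a stronger inhibitor of growth, a higher number a weaker inhibitor of growth), compound 2 gives the lower of the two numbers, and compound 1 stands above it by a gap beyond the usual scatter. Compound 3, `Nc1nnc(SC[C@H]2O[C@@H](OCc3noc(-c4ccc([N+](=O)[O-])cc4)n3)[C@@H]3OC4(CCCC4)O[C@@H]32)s1`, differs from compound 2 in one place: (5-amino-1,3,4-thiadiazol-2-yl)sulfanyl in place of acetoxy on a saturated chain carbon bound to a saturated ring carbon. Within the data shown here, no measured pair differs in this one place alone, so the size of the step is uncertain; a modest shift toward a higher number is expected, possibly none beyond the scatter, meaning an estimated step of a 1.5-fold higher number from compound 2 to compound 3 (0.17 log units; within the scatter). For compound 3 the estimated value is 25000 nM, in the range 10000 nM to 60000 nM.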

Compound 3, concentration for 50% growth inhibition: 28000 nM
Compound 3: middle estimate off by 1.1-fold (0.05 log units), on the low side; measured number inside the range.
By their numbers in this assay, from the lowest: compounds 2, 3 and 1 (each within the scatter of the next, the first and the last beyond it).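

In this assay, (5-amino-1,3,4-thiadiazol-2-yl)sulfanyl in place of acetoxy on a saturated chain carbon bound to a saturated ring carbon gives a 1.6-fold higher number from compound 2 to compound 3 (0.22 log units; within the scatter). This position therefore accepts a larger group carrying a five-membered aromatic ring, with no shift in growth inhibition beyond the scatter. No measured data explain this outcome. Still open, from the compounds shown here alone, is whether a smaller group here, such as a hydroxyl or an amine, would give a similar number. Going by these compounds, a carboxylic acid or a longer chain at this carbon is equally open.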